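The compounds below may be only part of what the source reports. "The series", "measured", "known", "first", "only" and "open" are said of these compounds alone.

Working notes on the series, all read in a functional assay on BT-474 cells (Homo sapiens) for inhibition, read by CellTiter-Glo, with a stated time of 72 h; on this read-out higher numbers stand for weaker inhibition and lower numbers for stronger inhibition. Compound 1 `C=C(F)C(=O)Nc1cc2c(Nc3ccc(Oc4cc5nncn5cn4)c(C)c3)ncnc2cc1OCC` gives 3.88 nM. Compound 3 `C=CC(=O)Nc1cc2c(Nc3ccc(Oc4cc5nncn5cn4)c(C)c3)ncnc2cc1OCC` gives 4.69 nM. Compound 2 `Cc1cc(Nc2ncnc3cc(O)c(NC(=O)/C=C/[C@H]4CCCN4C)cc23)ccc1Oc1ccn2ncnc2c1` gives 2.4 nM, which lies within the scatter of both other values, so the measured compounds do not separate on these numbers.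

The open structure is compound 4 `Cc1cc(Nc2ncnc3cc(O)c(NC(=O)/C=C/[C@H]4CCCN4C)cc23)ccc1Oc1ccn2ccnc2c1`. It departs from compound 2 at a single place: a group of 9 heavy atoms (7 carbon, 2 nitrogen; one five-membered aromatic ring with 2 hetero atoms, one six-membered aromatic ring with 1 hetero atom) in place of a group of 9 heavy atoms (6 carbon, 3 nitrogen; one five-membered aromatic ring with 3 hetero atoms, one six-membered aromatic ring with 1 hetero atom), on an oxygen on an aromatic ring.

Within the data shown here, only one measured step is available: a 1.2-fold higher number from compound 1 to compound 3 (0.08 log units; within the scatter). That step swaps hydrogen for fluoro on a double-bonded chain carbon bound to a carbonyl carbon, so it does not test the group on the oxygen. Among the measured compounds shown here, no measured pair isolates a change of that group, which leaves the evidence indirect. Compound 1 and compound 3 differ from compound 2 in more than one place, yet compound 1 at 3.88 nM and compound 3 at 4.69 nM stay within the scatter of compound 2.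

On this limited basis, no change beyond the scatter is expected, and the estimated step is a 1.3-fold higher number from compound 2 to compound 4 (0.10 log units; within the scatter). On these data alone, the range is kept wide since the exchanged group is untested. For compound 4 the expected value is 3 nM, with an estimated range of 1 nM to 9 nM.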

Compound 4, half-maximal inhibitory concentration: 4.63 nM
The estimate for compound 4 lay 1.5-fold (0.19 log units) below the measured number; the measured number falls inside the stated range.
By their numbers in this assay, from the lowest: compounds 2, 1, 4 and 3 (each within the scatter of the next).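

The pair of compound 2 and compound 4 gives the series its first direct reading of the group on an oxygen on an aromatic ring, which the fluoro-to-hydrogen step between compound 1 and compound 3 could not test: in this assay, the exchange gives a 1.9-fold higher number from compound 2 to compound 4 (0.29 log units; within the scatter) and the two compounds do not separate. At this place, therefore, the group with a five-membered aromatic ring with 2 hetero atoms and 2 hydrogen-bond acceptors stands in for the group with a five-membered aromatic ring with 3 hetero atoms and 3 hydrogen-bond acceptors without a step beyond the scatter, at least with the shared core and chain of these two compounds. No measurement bearing on why the pair reads this way accompanies these numbers.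

Still open, on these data alone, is whether the same holds for a simpler group on this oxygen, such as a plain phenyl or a pyridine ring, neither of which carries the fused five-membered ring. Also open, as far as these compounds go, is whether the exchange reads the same on the core and chain of compound 1 or compound 3, since this pair covers only one setting.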